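Series notes: pyridin-3-yl carboxamide analogue with methyl sulfonamide

This account rests on a few compounds, and the source may have more. Where it says the series, first, only, none or still open, it means among the compounds named here.

Measured so far:
compound 1 `COc1ccc(C(=O)NCc2ccc(CNS(=O)(=O)c3ccccc3)cc2)cc1` — 1000 nM
compound 2 `COc1ccc(C(=O)NCc2ccc(CNS(=O)(=O)c3ccc(C)cc3)cc2)cc1` — 100 nM
compound 3 `O=C(NCc1ccc(CNS(=O)(=O)c2ccccc2)cc1)c1ccncc1` — 10 nM

In an assay on MDA-MB-231 cells for binding affinity to C-X-C chemokine receptor type 4 (Homo sapiens), read by immunofluorescence and microscopy, with stated times of 10 min and 30 min (on this read-out lower numbers stand for an effect already at smaller amounts and higher numbers for an effect only at larger amounts of compound), compound 2 stands second highest of the three numbers; compound 1 gives a higher number, as shown by a 10-fold lower number from compound 1 to compound 2 (1.00 log units; beyond the scatter), and compound 3 gives a lower one. Compound 4 `Cc1ccc(S(=O)(=O)NCc2ccc(CNC(=O)c3cccnc3)cc2)cc1` differs from compound 2 by pyridin-3-yl in place of 4-methoxyphenyl on a carbonyl carbon. Among the measured compounds shown here, the step that bears on this is the one from compound 1 to compound 3, a 100-fold lower number from compound 1 to compound 3 (2.00 log units; beyond the scatter), which replaced the same 4-methoxyphenyl with pyridin-4-yl and was large. The entering group here is pyridin-3-yl, not pyridin-4-yl, so a step in the same direction but of less certain size is expected in this assay. Compound 4 is therefore estimated at 3 nM (range 0.5 nM to 30 nM), an expected step of a 33-fold lower number from compound 2 to compound 4 (1.52 log units; beyond the scatter).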

Compound 4, effective concentration (reported as EC, without a stated level of effect): > 1000 nM
Compound 4: a limit, no number; the forecaster's own chance of this, stated with the estimate: 0%; middle value at least 330-fold (2.52 log units) from the limit.
By their numbers in this assay, from the lowest: compound 3; then compound 2; then compound 1.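

The change on this carbonyl carbon does not run one way: an at least 10-fold higher number from compound 2 to compound 4 (1.00 log units; beyond the scatter) against a 100-fold lower number from compound 1 to compound 3 (2.00 log units; beyond the scatter) for pyridin-4-yl in place of the same 4-methoxyphenyl. A pyridine ring as such therefore does not go with the lower number seen for compound 3. The entry for compound 4 is a limit, not a number: the limit of > 1000 nM in this assay, at which 1 of the 4 values shown sits.

The two steps differ both in the pyridine isomer and in the methyl on the sulfonyl aromatic ring, and the compounds shown do not separate these. On these data alone, how pyridin-2-yl or 4-aminophenyl would read on this carbonyl carbon also stays open.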